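The compounds below may be only part of what the source reports. "The series", "measured", "known", "first", "only" and "open" are said of these compounds alone.

Measured compounds:
- compound 1 `COc1cc(C)cc(-c2c(-c3ccnc(-c4ccc(C(C)=O)cc4)c3)cnn2CC#N)c1`: 84%
- compound 2 `COc1cc(C)cc(-c2nn(CC#N)cc2-c2ccc(-c3cccc(C(C)=O)c3)nc2)c1`: 82%
- compound 3 `Cc1cc(O)cc(-c2nn(CC#N)cc2-c2ccnc(-c3ccc(Oc4ccccc4)cc3)c2)c1`: 85%

All three numbers come from a functional assay on MDA-MB-468 cells (Homo sapiens) for cytotoxicity, read by sulforhodamine B assay, with a stated time of 48 h, tested at 0.01 uM; on this read-out lower numbers stand for a stronger effect and higher numbers for a weaker effect at the one concentration tested. In this assay compound 3 gives 85%, the highest of the three numbers, but compound 1 with 84% and compound 2 with 82% both sit within the scatter of compound 3, so no order among the three can be read, and all three point to a weak effect at this concentration. Going by the values given here, no pair of measured compounds differs in one place only, so the series itself gives no step against which a single change can be sized.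

Compound 4 `Cc1cc(O)cc(-c2nn(CC#N)cc2-c2ccnc(-c3ccc(N(C)C)cc3)c2)c1` has not been measured. Its difference from compound 3 is dimethylamino in place of phenoxy on an aromatic carbon. Among the compounds with values here, with the three measured values lying in a narrow band and no comparable step available, the expected step, a number 1 percentage points lower from compound 3 to compound 4 (within the scatter), is estimated to stay within the scatter rather than move the read-out clearly in either direction. In this assay compound 4 is expected to give 84%, with a range from 70% to 97%.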

Compound 4, a percentage reported as activity, at one concentration (the size of the read-out at that concentration, not a potency): 91%
The estimate for compound 4 lay 7 percentage points below the measured number; the measured number falls inside the stated range.
By their numbers in this assay, from the lowest: compounds 2, 1, 3 and 4 (each within the scatter of the next).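

In this assay the series gains its first comparison that differs in one place, with a number 6 percentage points higher from compound 3 to compound 4 (within the scatter) on exchanging phenoxy for dimethylamino on an aromatic carbon, para to a large group. At this position, therefore, a group of 7 heavy atoms with a six-membered aromatic ring of carbon only gives way to one of 3 heavy atoms with no ring, and the read-out does not move beyond the scatter at the one concentration tested. Nothing available explains this result or assigns a role to either group.

A single exchange leaves open whether a different group at this position, such as a carboxylic acid or a morpholine ring, would separate from phenoxy in this read-out. Also open, going by these compounds, is whether phenoxy and dimethylamino would stay within the scatter of each other at higher concentrations.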